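A Second Methoxy on the Aryl Ring of Compound 1

A few compounds are considered here, and "the series" means these few. Any claim that something is new, unique, unknown or untested is made for them only; others in the source may bear on it.

Two chalcone-type compounds sharing a pyrazole-linked core were examined for cytotoxicity. Compound 1 `COc1ccc(-c2cc(/C=C/C(=O)c3ccc(N)cc3)[nH]n2)cc1` was tested in a functional assay on SN12C cells (Homo sapiens) for cytotoxicity, read by sulforhodamine B assay, with a stated time of 48 h, tested at 1 uM (a lower number here means a stronger effect, a higher number a weaker effect of the compound at the concentration tested), and gave 76%. Compound 2 `COc1ccc(C(=O)/C=C/c2cc(-c3cc(OC)c(OC)c(OC)c3)n[nH]2)cc1`, which carries a different arrangement of substituents around the same core, gave 91% in this assay. Of these two numbers, compound 1 stands at the lower end, and the gap between compound 1 and compound 2 lies beyond the usual scatter of this kind of measurement, so compound 1 is the stronger of the pair at the concentration tested.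

Compound 3 `COc1ccc(-c2cc(/C=C/C(=O)c3ccc(N)cc3)[nH]n2)cc1OC` has not yet been measured. It differs from compound 1 by methoxy in place of hydrogen on an aromatic carbon. The added group sits ortho to a methoxy group already present on that ring.

For the measured compounds named here, no measured pair in this set isolates such a change, so the expected step from compound 1 to compound 3 in this assay can only be a cautious one: a small shift, expected at a number 4 percentage points lower from compound 1 to compound 3 (within the scatter), most likely within the scatter and, if anything, towards a slightly stronger effect. On that basis compound 3 is expected to give about 72% in this assay, with a plausible range from 55% to 90%.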

Compound 3, a percentage reported as activity, at one concentration (the size of the read-out at that concentration, not a potency): 93%
The estimate for compound 3 lay 21 percentage points below the measured number; measured number outside the range, above it.
By their numbers in this assay, from the lowest: compound 1; then compounds 2 and 3 (each within the scatter of the next).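

The comparison of compound 1 with compound 3 shows that this position on the methoxy-bearing ring is not indifferent in this assay: methoxy in place of hydrogen, ortho to a methoxy group and meta to a large group, gives a number 17 percentage points higher from compound 1 to compound 3 (beyond the scatter), a modest step towards a weaker effect at the concentration tested. The entering group has only 2 heavy atoms, no ring and no net charge, yet this addition is enough to carry the read-out beyond the scatter. Nothing measured here bears on why the step occurs.

The compounds shown leave open whether the step belongs to methoxy itself or to any group at this position, a question that a fluorine, a methyl or a hydroxyl group in the same place would help to settle. They also leave open whether the same addition would give a similar step if the amino group of compound 1 were replaced by an acetamide or a nitro group.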